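Halogen pattern swap on the chalcone arm

The source may report more compounds than this note shows. Statements on the series, on what has been measured and on what is new or still open speak of the compounds shown alone.

Among the compounds with values here, compound 1 `O=C(COc1ccc(C(=O)/C=C/c2ccc(Cl)cc2Cl)cc1)N[C@H]1CCOC1=O` is the only member of this set with a numeric result in a functional assay on MGC-803 cells (Homo sapiens) for antiproliferative activity, read by MTT assay, with a stated time of 72 h (a lower number here means a stronger inhibitor, a higher number a weaker inhibitor), where compound 1 gives 26500 nM. The two other measured members return limits rather than numbers. Compound 2 `O=C1OCC[C@@H]1NC(=S)SCCOc1ccc([N+](=O)[O-])cc1` sits at the limit of > 100000 nM in this assay, at which 1 of the 3 values shown sits, and its recorded value in this assay, > 100000 nM, is a limit. Compound 3 `CC(C)c1ccc(NCC(=O)N[C@H]2CCOC2=O)cc1` sits at the limit of > 64000 nM in this assay, at which 1 of the 3 values shown sits, and its recorded value in this assay, > 64000 nM, is likewise a limit.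

Compound 4 `O=C(COc1ccc(C(=O)/C=C/c2cccc(Br)c2)cc1)N[C@H]1CCOC1=O` has not yet been measured. It differs from compound 1 in one place: 3-bromophenyl in place of 2,4-dichlorophenyl on a double-bonded chain carbon bound to a double-bonded chain carbon. Within the data shown here, the core of compound 1, with its lactone amide and enone chain, is kept unchanged, and no step between two measured compounds in this set shows how this assay answers a change of the aryl group on that chain. With nothing in the set pointing either way, the move is expected to stay close to the scatter. Compound 4 is therefore estimated at 30000 nM, with a range from 10000 nM to 90000 nM. The expected step is a 1.1-fold higher number from compound 1 to compound 4 (0.05 log units; within the scatter).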

Compound 4, half-maximal inhibitory concentration: 11900 nM
Estimate against measurement, compound 4: 2.5-fold (0.40 log units) above; the range from low to high includes it.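

In this assay, within the data shown here, 3-bromophenyl in place of 2,4-dichlorophenyl gives a 2.2-fold lower number from compound 1 to compound 4 (0.35 log units; beyond the scatter), the only step in this set that can be read. It shows that the number responds, modestly, to the aryl group on a double-bonded chain carbon bound to a double-bonded chain carbon, while the rest of the core of compound 1 stays unchanged. Nothing measured in the set bears on the reason for this step.

The swap changes the kind of halogen, the number of halogens and their places on the phenyl all at once, and the compounds shown cannot separate these changes. On these data alone, it also stays open whether a phenyl carrying an amine or a carboxylic acid in this place would lower the number further or raise it.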